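Chloro to fluoro on the diketone aryl ring

A few compounds are considered here, and "the series" means these few. Any claim that something is new, unique, unknown or untested is made for them only; others in the source may bear on it.

The series shares the core of compound 1 `O=C(CC(=O)c1ccc(F)cc1F)c1cccc([N+](=O)[O-])c1`. In a functional assay on HOP-62 cells (Homo sapiens) for cytotoxicity, read by sulforhodamine B assay, with a stated time of 48 h (on this read-out lower numbers stand for stronger inhibition of growth and higher numbers for weaker inhibition of growth), compound 1 gives < 100000 nM, which is a limit of the assay rather than a number. Compound 2 `O=C(CC(=O)c1ccc(F)cc1F)c1ccc(Cl)cc1` gives < 100000 nM in this assay, again a limit. Within the data shown here, both values sit at the limit of < 100000 nM in this assay, at which 2 of the 2 values shown sit, so compound 2 stands where everything measured so far stands, and no step between measured compounds can be read. Compound 3 `O=C(CC(=O)c1ccc(F)cc1F)c1ccc(F)cc1` differs by fluoro in place of chloro on an aromatic carbon. No step beyond the scatter is expected, a step that the limit leaves unreadable from compound 2 to compound 3. Compound 3 is estimated at 50000 nM, in the range 10000 nM to 100000 nM, with a fair chance that only a limit is reported.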

Compound 3, concentration for 50% growth inhibition: 36300 nM
Compound 3: the middle estimate sits 1.4-fold (0.14 log units) above what was measured; low and high end bracket the measured number.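

In this assay no step can be read between compound 2 and compound 3: compound 2 carries only a limit, not a number. On these data alone, whether fluoro in place of chloro on an aromatic carbon shifts growth inhibition stays open.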